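A few compounds are considered here, and "the series" means these few. Any claim that something is new, unique, unknown or untested is made for them only; others in the source may bear on it.

Measured compounds in the series so far:

compound 1, `O=C(O)Cc1sc(Cc2ccccc2)nc1-c1ccc(Cl)cc1`, an in vitro functional assay on HEK285-7 cells for antagonist activity at prostaglandin D2 receptor 2 (Homo sapiens), read by BRET and beta-arrestin recruitment; on this read-out higher numbers stand for larger maximal responses and lower numbers for smaller maximal responses: 50%
compound 2, `O=C(O)Cc1sc(C(c2ccc(F)cc2)c2ccc(F)cc2)nc1-c1ccnc(F)c1`, this assay: 80%

Compound 2 holds the higher of the two numbers in this assay; compound 1 sits a good distance lower, and that gap is beyond the usual scatter of the measurement. Both compounds share the same core carrying the carboxymethyl group, and they differ at more than one position, so nothing can be read from the pair about any single change.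

The next compound, compound 3, `O=C(O)Cc1sc(C(c2ccc(F)cc2)c2ccc(F)cc2)nc1-c1ccco1`, changes a single group on the core of compound 2:

furan-2-yl in place of 2-fluoropyridin-4-yl on an aromatic carbon

Within the data shown here, no measured pair isolates this replacement, so its effect in this assay is unknown. A moderate drop is expected, a number 12 percentage points lower from compound 2 to compound 3 (beyond the scatter), which may or may not exceed the scatter. Compound 3 is estimated to reach 68% in this assay, within a range from 45% to 92%.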

Compound 3, largest response reached (reported as efficacy), in percent of the reference or control that the assay uses: 80%
Compound 3: middle estimate off by 12 percentage points, on the low side, and the stated range covers the measured number.
By their numbers in this assay, from the lowest: compound 1; then compounds 2 and 3 (each within the scatter of the next).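

Replacing 2-fluoropyridin-4-yl with furan-2-yl, on the aromatic carbon next to the ring nitrogen, gives no change at the digits printed from compound 2 to compound 3 (within the scatter) in this assay. For this pair, the position accepts a five-membered aromatic ring with 1 hetero atom in place of a six-membered one, although the entering group has fewer heavy atoms and carries oxygen instead of nitrogen and fluorine. No available evidence bears on this result.

From the compounds shown here alone, whether the position also tolerates a non-aromatic group, such as a morpholine ring, an amine or a short alkyl chain, remains open. Among these compounds, it is also open whether furan-2-yl gives the same outcome when the group that compound 1 carries on the ring atom bearing the large group stands in place of the one in compound 2.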